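Thiazole for Oxazole on a Fluorophenyl Triazole Acetamide

The compounds below may be only part of what the source reports. "The series", "measured", "known", "first", "only" and "open" are said of these compounds alone.

The series starts from compound 1 `Cc1cc(NC(=O)Cn2cc(-c3ccc(Cl)cc3)nn2)no1`. In a functional assay on BMDM cells (Mus musculus, strain C57BL/6) for inhibition, with a stated time of 2 days (a lower number here means a stronger inhibitor, a higher number a weaker inhibitor), compound 1 gives 1910 nM. Compound 2 `Cc1csc(NC(=O)Cn2cc(-c3ccc(Cl)cc3)nn2)n1` carries the change (4-methyl-1,3-thiazol-2-yl in place of 5-methyl-1,2-oxazol-3-yl on an amide-type nitrogen), and in this assay compound 2 gives 520 nM, a step described as a 3.7-fold lower number from compound 1 to compound 2 (0.57 log units; beyond the scatter). Compound 3 `Cc1cc(NC(=O)Cn2cc(-c3ccc(F)cc3)nn2)no1` differs from compound 1 by fluoro in place of chloro on an aromatic carbon. In this assay compound 3 reaches only a limit of the assay, > 30000 nM. The step is recorded as an at least 15-fold higher number from compound 1 to compound 3 (1.19 log units; beyond the scatter), where compound 3 sits at the limit of > 30000 nM in this assay, at which 1 of the 3 values shown sits.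

Compound 4 `Cc1csc(NC(=O)Cn2cc(-c3ccc(F)cc3)nn2)n1` has not been measured. It differs from compound 3 by 4-methyl-1,3-thiazol-2-yl in place of 5-methyl-1,2-oxazol-3-yl on an amide-type nitrogen, the same change that separates compound 1 from compound 2, made at the same place. Beside the measured step of a 3.7-fold lower number from compound 1 to compound 2 (0.57 log units; beyond the scatter), the step for compound 4 is expected to be an at least 1.5-fold lower number from compound 3 to compound 4 (0.17 log units; that floor lies within the scatter), which rests on compound 3 being known only as a limit in this assay. Compound 4 is therefore estimated at 20000 nM in this assay, with a range from 5000 nM to 60000 nM.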

Compound 4, half-maximal inhibitory concentration: 250 nM
For compound 4 the middle estimate is 80-fold (1.90 log units) above the measured one, and the stated range ends above it.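

In this assay the thiazole change gives an at least 120-fold lower number from compound 3 to compound 4 (2.07 log units; beyond the scatter), so it lowers the number on both cores, yet its size does not carry over from one core to the other: the same change on two cores in this assay, a 3.7-fold lower number (0.57 log units; beyond the scatter) from compound 1 to compound 2 and an at least 120-fold lower number (2.07 log units; beyond the scatter) from compound 3 to compound 4, at least 32-fold (1.51 log units) apart, beyond the scatter of two such steps. With the 4-methyl-1,3-thiazol-2-yl group in place, fluoro for chloro gives a 2.1-fold lower number from compound 2 to compound 4 (0.32 log units; beyond the scatter), opposite in direction to the same swap with the 5-methyl-1,2-oxazol-3-yl group, so in these compounds the two changes do not act independently: the same change on two cores in this assay, an at least 15-fold higher number (1.19 log units; beyond the scatter) from compound 1 to compound 3 and a 2.1-fold lower number (0.32 log units; beyond the scatter) from compound 2 to compound 4, at least 32-fold (1.51 log units) apart, beyond the scatter of two such steps. Compound 3 is known only as a limit, so the direction of the thiazole change is shown here, while the true size of that step on this core is not: the limit of > 30000 nM in this assay, at which 1 of the 4 values shown sits.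

These four compounds leave open whether the same dependence would appear with a methoxy group or a nitrile in place of the halogen on that aromatic carbon. Also open, as far as these compounds go, is how an unmethylated thiazol-2-yl group on the amide-type nitrogen would behave on either core.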